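The source may hold more compounds than are shown below. What is called first, only, known or untested is meant among the compounds shown, and "the series" means these compounds.

In an ADME assay on MDBK cells (Bos taurus) for cytotoxicity, read by MTT assay, with a stated time of 96 h (on this read-out lower numbers stand for higher toxicity in this test and higher numbers for lower toxicity in this test), compound 3 `CSCCCNC(=S)Nc1cccc(C(F)(F)F)c1` gives > 100000 nM, which is a limit of the assay and not a number. Compound 1 `CCNC(=S)Nc1cccc(C(F)(F)F)c1` gives > 100000 nM, also a limit. Together they make up (the limit of > 100000 nM in this assay, at which 2 of the 3 values shown sit). Compound 2 `FC(F)(F)c1cccc(NC(=S)Nc2cccc(Br)c2)c1`, which carries a 3-bromophenyl group, gives a true number of 10000 nM.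

Compound 4 `Fc1cccc(NC(=S)Nc2cccc(C(F)(F)F)c2)c1` has 3-fluorophenyl in place of 3-(methylsulfanyl)propyl on an amide-type nitrogen.

For the measured compounds named here, two measured steps bear on this change, and both lie beyond the scatter: an at least 10-fold higher number from compound 2 to compound 3 (1.00 log units; beyond the scatter) and an at least 10-fold lower number from compound 1 to compound 2 (1.00 log units; beyond the scatter). Each links a compound with an open chain on that nitrogen to compound 2, with its substituted phenyl group. The third, a step that the two limits leave unreadable from compound 1 to compound 3, tells nothing, since both ends are limits.

Compound 4 also carries a substituted phenyl group, so its number is expected to fall close to that of compound 2, which gives 10000 nM. The expected change is an at least 5.5-fold lower number from compound 3 to compound 4 (0.74 log units; beyond the scatter). For compound 4, the estimated value is 18000 nM, within an expected range of 6000 nM to 70000 nM.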

Compound 4, half-maximal cytotoxic concentration: 10000 nM
The estimate for compound 4 lay 1.8-fold (0.26 log units) above the measured number; the range from low to high includes it.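

In this assay, fluoro in place of bromo on the aromatic carbon gives no change at the digits printed from compound 2 to compound 4 (within the scatter), so the number does not separate these two halogens on the phenyl group. A second substituted phenyl group can now be set against the open chains, with an at least 10-fold lower number from compound 3 to compound 4 (1.00 log units; beyond the scatter) and an at least 10-fold lower number from compound 1 to compound 4 (1.00 log units; beyond the scatter), so the lower number is no longer tied to the 3-bromophenyl group alone. Both of these steps start from a limit and not a true number, so they give only a minimum size: the limit of > 100000 nM in this assay, at which 2 of the 4 values shown sit.

The compounds shown leave open whether the lower number needs an aromatic ring at all, or would also appear with a saturated ring such as cyclohexyl. They also leave open whether a plain phenyl group without a halogen, or a 3-methoxyphenyl group, would give the same number.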